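This account rests on a few compounds, and the source may have more. Where it says the series, first, only, none or still open, it means among the compounds named here.

Working notes on the series. In a functional assay on HCT-116 cells (Homo sapiens) for cytotoxicity, read by MTT assay, with a stated time of 48 h (on this read-out lower numbers stand for stronger inhibition and higher numbers for weaker inhibition), compound 1 `COc1cc(/C=C/C(=O)C2=C(/C=C/c3ccc(O)c(OC)c3)NC(=O)NC2c2ccccc2)ccc1O` gives 25000 nM, and compound 2 `COc1cc(/C=C/C(=O)C2=C(/C=C/c3ccc(O)c(OC)c3)NC(=S)NC2c2ccccc2)ccc1O` gives 100000 nM. Compound 2 therefore holds the higher of the two numbers and is the weaker of the pair, with a gap to compound 1 that lies beyond the scatter. Compound 3 `COc1cc(/C=C/C(=O)C2=C(/C=C/c3ccc(O)c(OC)c3)NC(=S)NC2c2ccccc2Cl)ccc1O` departs from compound 2 by a single change, chloro in place of hydrogen on an aromatic carbon, turning phenyl into 2-chlorophenyl. Among the compounds with values here, no measured pair shows the effect of this substitution, so the expectation is tentative: a modest move towards a lower number in this assay, possibly none beyond the scatter. Within the data shown here, compound 2 stands at 100000 nM, the higher end of the numbers so far, which favours that direction. The estimated step is a 2.0-fold lower number from compound 2 to compound 3 (0.30 log units; within the scatter). For compound 3 the expected value is 50000 nM, with an estimated range of 15000 nM to 120000 nM.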

Compound 3, half-maximal inhibitory concentration: 100000 nM
For compound 3 the middle estimate is 2.0-fold (0.30 log units) below the measured one; measured number inside the range.
By their numbers in this assay, from the lowest: compound 1; then compounds 2 and 3 (each within the scatter of the next).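

In this assay the change from phenyl to 2-chlorophenyl gives no change at the digits printed from compound 2 to compound 3 (within the scatter). Within the data shown here, the earlier compounds differ only at the carbonyl and its sulfur counterpart and both carry an unsubstituted phenyl, so this is the first reading of a substituent on that six-membered aromatic ring: a single chloro on the aromatic carbon ortho to a large group leaves the number where it stood, with compound 3 at 100000 nM. No data at hand bear on the reason for this result.

The compounds shown leave open whether a different group at this carbon, such as a methoxy group, an amine or a carboxylic acid, would shift the number. They also leave open whether chloro would read the same on compound 1, which carries the carbonyl and holds the lower number, 25000 nM.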